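Cytotoxicity notes on the aminothiazole series, compound 4

The source may hold more compounds than are shown below. What is called first, only, known or untested is meant among the compounds shown, and "the series" means these compounds.

In an ADME assay on HepG2 2.2.15 cells (Homo sapiens) for cytotoxicity (on this read-out lower numbers stand for higher toxicity in this test and higher numbers for lower toxicity in this test), compound 1 `O=C(Nc1ncc(Cc2ccc(Cl)cc2)s1)c1ccc(F)cc1F` is reported as "not toxic" (no number reported) and compound 3 `O=C(Nc1ncc(C(OCc2ccc(Br)cc2)c2ccccc2)s1)c1cccs1` likewise as "not toxic" (no number reported), neither with a number. Compound 2 `CC(C)(C)OC(=O)Nc1ncc(C(Oc2ccc3cc(Br)ccc3c2)c2ccc(Cl)cc2)s1` is given only as a limit of this assay, > 50000 nM. Compound 3 therefore stands without a single number; of the other two entries one is the limit and one is again a result without a number, so the three compounds cannot be ordered against one another, and the one limit shown is the limit of > 50000 nM in this assay, at which 1 of the 3 values shown sits.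

Compound 4 `O=C(Nc1ncc(C(OCc2ccc(F)cc2Br)c2ccccc2)s1)c1cccs1` is not yet measured. It differs from compound 3 in one place: 2-bromo-4-fluorophenyl in place of 4-bromophenyl on a saturated chain carbon bound to an oxygen on a saturated carbon. Going by the values given here, since no step between measured compounds exists in this assay, the size of the change from compound 3 to compound 4 has no precedent; nothing among compounds 1, 2 and 3 separates cytotoxic from non-cytotoxic members, and no direction can be read from them. The expectation is therefore no shift beyond the scatter, with compound 4 expected, like compound 2, to fall at or beyond the reporting limit of this assay.

Compound 4 is estimated at 50000 nM in this assay, with a range of 20000 nM to 100000 nM.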

Compound 4, half-maximal cytotoxic concentration: "not toxic" (no number reported)
The entry for compound 4 holds no number; there is nothing to compare the estimate with.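

In this assay, going by these compounds alone, compound 3 gives "not toxic" (no number reported) and compound 4 gives "not toxic" (no number reported), so no step between the two can be read. The compounds shown leave open at what concentration, if any, cytotoxicity would appear in this series, as compound 2 carries the only figure and that figure is a limit: the limit of > 50000 nM in this assay, at which 1 of the 4 values shown sits.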